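This account rests on a few compounds, and the source may have more. Where it says the series, first, only, none or still open, it means among the compounds named here.

Measured so far: compound 1 `COc1cc(-c2cc(/C=C/C(=O)c3ccc(N)cc3)[nH]n2)cc(OC)c1OC` gives 81% in a functional assay on SF-268 cells (Homo sapiens) for cytotoxicity, read by sulforhodamine B assay, with a stated time of 48 h, tested at 1 uM; a higher number here means a weaker effect of the compound at the concentration tested, a lower number a stronger effect; compound 2 `COc1cc(-c2cc(/C=C/C(=O)c3ccc(Cl)c(Cl)c3)[nH]n2)cc(OC)c1OC` gives 92%.

Among the measured compounds shown here, compound 2 stands highest of the two numbers; the single measured step, a number 11 percentage points higher from compound 1 to compound 2 (beyond the scatter), lies beyond the scatter. Compound 3 `COc1ccc(C(=O)/C=C/c2cc(-c3cc(OC)c(OC)c(OC)c3)n[nH]2)cc1OC` differs from compound 2 in one place: 3,4-dimethoxyphenyl in place of 3,4-dichlorophenyl on a carbonyl carbon. For the measured compounds named here, no measured step exchanges these two groups, so the step from 4-aminophenyl to 3,4-dichlorophenyl bears on it only loosely, and it was modest. Compound 3 is therefore expected to give 85%, between 70% and 98%. The expected step of a number 7 percentage points lower from compound 2 to compound 3 (within the scatter) stays within the scatter.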

Compound 3, a percentage reported as activity, at one concentration (the size of the read-out at that concentration, not a potency): 89%
Estimate against measurement, compound 3: 4 percentage points below; measured number inside the range.
By their numbers in this assay, from the lowest: compounds 1, 3 and 2 (each within the scatter of the next, the first and the last beyond it).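

Exchanging 3,4-dichlorophenyl for 3,4-dimethoxyphenyl on a carbonyl carbon gives a number 3 percentage points lower from compound 2 to compound 3 (within the scatter) in this assay, so this change does not separate the two compounds. Against 4-aminophenyl, the same group gives a number 8 percentage points higher from compound 1 to compound 3 (within the scatter), which places compound 3 within the scatter of both compounds whose own gap lies beyond it. No measurement shown here offers an explanation for these numbers.

From the compounds shown here alone, it remains open how a carboxylic acid or a plain phenyl on that carbonyl carbon would read. The compounds shown also leave open how these groups compare at any other concentration.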